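This account rests on a few compounds, and the source may have more. Where it says the series, first, only, none or still open, it means among the compounds named here.

In a functional assay on HCC827 cells (Homo sapiens) for inhibition, read by fluorescence, with a stated time of 72 h (on this read-out lower numbers stand for stronger inhibition of growth and higher numbers for weaker inhibition of growth), compound 1 (`CCCCCCn1cnc2c(Nc3ccc(Cl)cc3)nc(N[C@H]3CC[C@H](N)CC3)nc21`) gives 11700 nM and compound 2 (`CCCCn1cnc2c(Nc3cc(OC)cc(OC)c3)nc(N[C@H]3CC[C@H](N)CC3)nc21`) gives 20100 nM so that the two stand within the scatter of each other. Compound 3 (`CCCCn1cnc2c(Nc3ccc(Cl)cc3)nc(N[C@H]3CC[C@H](N)CC3)nc21`) carries 4-chlorophenyl in place of 3,5-dimethoxyphenyl on a nitrogen on an aromatic ring. Within the data shown here, no measured pair shows this change alone. Compound 1 also bears 4-chlorophenyl and gives 11700 nM so no step beyond the scatter is expected in this assay. The estimated step is a 1.5-fold lower number from compound 2 to compound 3 (0.19 log units; within the scatter) and points toward stronger inhibition of growth. The estimated value for compound 3 is 13000 nM with an expected range from 5500 nM to 30000 nM in this read-out.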

Compound 3, concentration for 50% growth inhibition: 10800 nM
Beside the measured number, compound 3's estimate is 1.2-fold (0.08 log units) above it; measured number inside the range.
By their numbers in this assay, from the lowest: compounds 3, 1 and 2 (each within the scatter of the next).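

In this assay, 4-chlorophenyl in place of 3,5-dimethoxyphenyl on a nitrogen on an aromatic ring can now be read alone, and a 1.9-fold lower number from compound 2 to compound 3 (0.27 log units; within the scatter) shows that this exchange of aryl groups stays within the scatter. Hydrogen in place of ethyl on a saturated chain carbon, four bonds along the chain from an aromatic nitrogen, can also be read alone, and a 1.1-fold lower number from compound 1 to compound 3 (0.03 log units; within the scatter) likewise stays within the scatter. No measured evidence bears on these results. The compounds shown leave open whether an amine or a carboxylic acid on the aryl group, or a much longer chain, would give a step beyond the scatter.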